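Adding a Second Chloro Group to a Rearranged Core

The source may hold more compounds than are shown below. What is called first, only, known or untested is meant among the compounds shown, and "the series" means these compounds.

Measured compounds:
compound 1 `ClCc1ccccc1Cn1cnc2c(Cl)nc(Cl)nc21` with 3090 nM
compound 2 `ClCc1ccccc1Cn1cnc2c(Cl)ncnc21` with 4360 nM
compound 3 `ClCc1ccccc1Cn1cnc2ncnc(Cl)c21` with 17400 nM

All three compounds were tested in a functional assay on NCI-H23 cells (Homo sapiens) for cytotoxicity, read by sulforhodamine B assay, with a stated time of 48 h; a higher number here means a weaker inhibitor of growth, a lower number a stronger inhibitor of growth. Compound 2 and compound 1 share one core and differ by a single group: chloro in place of hydrogen on an aromatic carbon. That change gave a 1.4-fold lower number from compound 2 to compound 1 (0.15 log units; within the scatter), so the two compounds cannot be told apart by this measurement.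

Compound 3 is built from the same atoms as compound 2, but they are joined differently, so the two have different cores; the difference between the two cores is not broken down here. In this assay compound 3 gives the highest number of the three, and its gap to compound 2 and to compound 1 lies beyond the scatter.

Compound 4 `ClCc1ccccc1Cn1cnc2nc(Cl)nc(Cl)c21` has not yet been measured. It differs from compound 3 in the same way that compound 1 differs from compound 2: chloro in place of hydrogen on an aromatic carbon. The place of the change is described in the same words in both pairs, so this is the same change applied to the core of compound 3 instead of the core of compound 2.

Because the earlier step was a 1.4-fold lower number from compound 2 to compound 1 (0.15 log units; within the scatter), the step to compound 4 is expected to be small as well, about a 1.3-fold lower number from compound 3 to compound 4 (0.13 log units; within the scatter). Among the compounds with values here, compound 4 is therefore estimated to give 13000 nM in this assay, with a range from 6000 nM to 26000 nM, since the only guide is a single small step measured on a different core.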

Compound 4, concentration for total growth inhibition: 40700 nM
Compound 4: middle estimate off by 3.1-fold (0.50 log units), on the low side; measured number above the stated range.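

In this assay the chloro group that replaces hydrogen on the aromatic carbon between two ring nitrogen atoms gave a 2.3-fold higher number from compound 3 to compound 4 (0.37 log units; beyond the scatter) and so went with weaker growth inhibition on the core of compound 3. The same change therefore did not behave alike on the two cores, and the difference between its two steps is larger than repeated measurements would explain: the same change on two cores in this assay, a 1.4-fold lower number (0.15 log units; within the scatter) from compound 2 to compound 1 and a 2.3-fold higher number (0.37 log units; beyond the scatter) from compound 3 to compound 4, 3.3-fold (0.52 log units) apart, beyond the scatter of two such steps. This shows that, for these two pairs, the step measured on one core was not a reliable guide to the step on the other, but it does not show why the cores differ or how the change would behave on any further core.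

The compounds shown carry only chloro or hydrogen at this ring carbon, so it remains open whether an amine, a methoxy group or a longer chain there would also give different results on the two cores. Going by these compounds, it also remains open whether the same contrast between the cores would appear in another cell line or after a different exposure time.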